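The source may hold more compounds than are shown below. What is called first, only, known or untested is meant among the compounds shown, and "the series" means these compounds.

Three compounds have been measured in an ADME assay on HeLa cells (Homo sapiens) for cytotoxicity, read by ATP content, with a stated time of 3 days; on this read-out higher numbers stand for lower toxicity in this test and lower numbers for higher toxicity in this test:

Compound 1 `CS(=O)(=O)c1ccc(-n2c(=O)n(Cc3cc4cc(Cl)ccc4n3CCCC#N)c3cnccc32)cc1` gives > 50000 nM.
Compound 2 `CC(C)CCn1c(Cn2c(=O)n(C3CC3)c3ccncc32)nc2nc(Cl)ccc21` gives > 50000 nM.
Compound 3 `O=c1n(Cc2cc3cc(Cl)ccc3n2CCCC(F)(F)F)c2cnccc2n1C1CC1` gives > 50000 nM.

Each of these readings is a limit of the test rather than a number, so compound 1 stands where the other two stand: at the limit of > 50000 nM in this assay, at which 3 of the 3 values shown sit. For the measured compounds named here, no step between measured compounds can be drawn from such readings, and no ranking among compound 1, compound 2 and compound 3 is possible.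

Compound 4 `N#CCCCn1c(Cn2c(=O)n(-c3ccncc3F)c3ccncc32)cc2cc(Cl)ccc21` differs from compound 1 by 3-fluoropyridin-4-yl in place of 4-(methylsulfonyl)phenyl on an aromatic nitrogen. With every measured value sitting at the limit, the step from compound 1 to compound 4 is expected as a step that the limit leaves unreadable from compound 1 to compound 4, that is none beyond the scatter. Compound 4 is therefore expected to give about 60000 nM in this assay, within 20000 nM to 200000 nM, most likely again only as a limit.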

Compound 4, half-maximal cytotoxic concentration: > 50000 nM
Compound 4 ended at the assay's limit (the forecaster's own chance of this, stated with the estimate: 85%); the middle value does not contradict the limit.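

No step can be read between compound 1 and compound 4, since both readings are limits of the test: the limit of > 50000 nM in this assay, at which 4 of the 4 values shown sit. The compounds shown leave open how far each lies beyond that limit, and which change would bring a reading within range.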